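Anilide thiocarbamates: methyl-to-hydroxyl swap on the anilide ring

This account rests on a few compounds, and the source may have more. Where it says the series, first, only, none or still open, it means among the compounds named here.

Measured in a functional assay on MCF7 cells (Homo sapiens) for cytotoxicity, read by MTT assay, with a stated time of 72 h; a lower number here means a stronger inhibitor, a higher number a weaker inhibitor:
compound 1 `Cc1cccc(NC(=O)CSC(=S)N[C@H]2CCOC2=O)c1` gives 63200 nM
compound 2 `O=C(CSC(=S)N[C@H]1CCOC1=O)Nc1ccc(Cl)cc1Cl` gives 29200 nM

Compound 1 stands at the higher of the two numbers in this assay; compound 2 sits beyond the scatter below it, so compound 1 is the weaker of the two. The pair differs at the anilide ring only, and nothing else in the shared core has been varied so far.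

Compound 3 `O=C(CSC(=S)N[C@H]1CCOC1=O)Nc1ccc(O)cc1` carries the change 4-hydroxyphenyl in place of 3-methylphenyl on an amide-type nitrogen relative to compound 1. Going by the values given here, with only two measured compounds and no single-site comparison between them, the data give no basis for a direction: the step from compound 1 to compound 3 is expected to be small, with a hydrogen-bond donor and acceptor entering where none stood, and no movement beyond the scatter is assumed. The expected step is a 1.3-fold lower number from compound 1 to compound 3 (0.10 log units; within the scatter). For compound 3 the estimate in this assay is 50000 nM, with a range from 15000 nM to 150000 nM, kept wide to reflect the absence of any prior step of this kind.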

Compound 3, half-maximal inhibitory concentration: > 128000 nM
Compound 3: no number, only a limit (the forecaster's own chance of this, stated with the estimate: 15%); at least 2.5-fold (0.40 log units) between middle value and limit.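

In this assay compound 3 gives no number, only a limit: the limit of > 128000 nM in this assay, at which 1 of the 3 values shown sits.

Read as a step, 4-hydroxyphenyl in place of 3-methylphenyl on the amide-type nitrogen gives an at least 2.0-fold higher number from compound 1 to compound 3 (0.30 log units; that floor lies within the scatter); the true difference may be larger, but what is secured goes no further than that floor. Going by these compounds alone, this is the first single-site comparison, and it gives the change a direction that the two earlier compounds could not: the ring carrying a hydrogen-bond donor and acceptor comes with no lower number in this assay, so this swap offers no gain in potency.

The swap alters both the group and its place on the ring, and the compounds shown do not separate the two contributions; a 4-methylphenyl or a 3-hydroxyphenyl anilide would speak to that directly. As far as these compounds go, whether a 4-methoxyphenyl or 4-aminophenyl ring behaves like 4-hydroxyphenyl also stays open, as does how far the true value of compound 3 lies past its limit.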